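A few compounds are considered here, and "the series" means these few. Any claim that something is new, unique, unknown or untested is made for them only; others in the source may bear on it.

Of the compounds shown here, three have been measured so far in a functional assay on P388 cells (Mus musculus); a lower number here means that less compound is needed, a higher number that more compound is needed for the effect. Compound 1 `Nc1ncn(C[C@@H]2CO[C@H](CO)O2)c(=O)n1` gives 90000 nM, and compound 3 `Nc1ncn(C[C@@H]2CO[C@@H](CO)O2)c(=O)n1` gives 70000 nM. Compound 2 `Cc1nn(C[C@H]2CO[C@H](CO)O2)c(=O)[nH]c1=O` has no exact number, only a limit of the assay, > 100000 nM.

Compound 4 `Cc1nn(C[C@@H]2CO[C@@H](CO)O2)c(=O)[nH]c1=O` is still unmeasured. Its structural change is the two compounds have the same atoms and bonds and differ only in configuration as drawn: 2 of 2 stereo elements differ (all stereocentres are inverted: mirror images); a stereocentre at a saturated ring carbon is drawn S in compound 2 and R in compound 4; a stereocentre at a saturated ring carbon is drawn S in compound 2 and R in compound 4. Put simply, it has the same atoms and bonds as compound 2 and is its mirror image, with all stereocentres inverted.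

For the measured compounds named here, only one measured step speaks to a change of configuration alone, and it is a smaller change, since only 1 of 2 stereo elements differ there. That step is a 1.3-fold lower number from compound 1 to compound 3 (0.11 log units; within the scatter), and it lies within the scatter. The pair behind it offers a clean comparison, given (the fact that compounds 1 and 3 differ only in the configuration as drawn). Going by the values given here, no measured pair shows a full inversion, so this guide is only partial. Among the compounds with values here, still, with a 1.3-fold lower number from compound 1 to compound 3 (0.11 log units; within the scatter) as the only guide, no step beyond the scatter is expected in this assay, and no direction can be favoured.

The estimated step, reckoned from the limit, is a number no higher from compound 2 to compound 4 (the limit leaves the size open). For compound 4 the expected value is 100000 nM, with an estimated range from 50000 nM to 200000 nM, and the result may well be reported only as a limit again.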

Compound 4, half-maximal effective concentration: > 100000 nM
Compound 4: no number, only a limit; the forecaster's own chance of this, stated with the estimate: 70%; the middle value sits exactly at the limit.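

In this assay compound 4 gives > 100000 nM, which is a limit of the assay and not a number. For the compounds shown here, compound 2 also has only a limit, and no step between these two mirror images can be read. The compounds shown leave open whether compound 2 and compound 4 differ at all in this assay.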